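This account rests on a few compounds, and the source may have more. Where it says the series, first, only, none or still open, it means among the compounds named here.

Measured so far in a functional assay (Pituitary gland cell) with Rattus norvegicus as the target; on this read-out higher numbers stand for an effect only at larger amounts of compound and lower numbers for an effect already at smaller amounts:
compound 1 `CC(C)[C@H](O)CNC(C)(C)CC(=O)N[C@@H]1CCc2ccccc2N(Cc2ccc(-c3ccccc3-c3nn[nH]n3)cc2)C1=O` gives 1000 nM;
compound 2 `CC(C)[C@@H](O)CNC(C)(C)CC(=O)N[C@@H]1CCc2ccccc2N(Cc2ccc(-c3ccccc3-c3nn[nH]n3)cc2)C1=O` gives 200 nM;
compound 3 `CC(C)(CC(=O)N[C@@H]1CCc2ccccc2N(Cc2ccc(-c3ccccc3-c3nn[nH]n3)cc2)C1=O)NC[C@H](O)CO` gives 10 nM.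

Compound 3 stands lowest of the three. The steps of a 20-fold lower number from compound 2 to compound 3 (1.30 log units; beyond the scatter) and a 100-fold lower number from compound 1 to compound 3 (2.00 log units; beyond the scatter) both run toward the diol; the step of a 5.0-fold lower number from compound 1 to compound 2 (0.70 log units; beyond the scatter) rests on (the fact that compounds 1 and 2 differ only in the configuration as drawn). Compound 4 `C[C@@H](O)CCNC(C)(C)CC(=O)N[C@@H]1CCc2ccccc2N(Cc2ccc(-c3ccccc3-c3nn[nH]n3)cc2)C1=O` carries 2-hydroxypropyl in place of 1,2-dihydroxyethyl on a saturated chain carbon bound to an amine nitrogen. One hydroxyl remains and the other is replaced by a methyl. The gains seen in a 20-fold lower number from compound 2 to compound 3 (1.30 log units; beyond the scatter) and a 100-fold lower number from compound 1 to compound 3 (2.00 log units; beyond the scatter) came with hydroxyls entering in place of carbon-only groups, so the reverse move here is expected to raise the number in this assay, by less than those steps since a hydroxyl is kept. Compound 4 is therefore expected at 100 nM, in the range 20 nM to 500 nM, a step of a 10-fold higher number from compound 3 to compound 4 (1.00 log units; beyond the scatter).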

Compound 4, concentration for half-maximal effect: 10 nM
Compound 4: the middle estimate sits 10-fold (1.00 log units) above what was measured, outside the stated range (below it).
By their numbers in this assay, from the lowest: compounds 3 and 4 (each within the scatter of the next); then compound 2; then compound 1.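

In this assay, the 1,2-dihydroxyethyl group can give way to 2-hydroxypropyl on this saturated chain carbon bound to an amine nitrogen, with one hydroxyl fewer: no change at the digits printed from compound 3 to compound 4 (within the scatter). The low number therefore does not depend on the diol, and the gain over 1-hydroxy-2-methylpropyl persists with a single hydroxyl: a 20-fold lower number from compound 2 to compound 4 (1.30 log units; beyond the scatter), and a 100-fold lower number from compound 1 to compound 4 (2.00 log units; beyond the scatter). Nothing at hand gives a reason for this result.

Open: what a plain propyl chain, an amine or a carboxylic acid would give here. Also open, going by these compounds, is whether the configuration of the remaining hydroxyl-bearing carbon matters.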